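Chalcone triazole series: aryl in place of carbinol

A few compounds are considered here, and "the series" means these few. Any claim that something is new, unique, unknown or untested is made for them only; others in the source may bear on it.

Measured so far:
compound 1 `COc1cc(/C=C/C(=O)c2cccc(-n3cc(C(C)(C)O)nn3)c2)ccc1O`: 19800 nM
compound 2 `COc1ccc(/C=C/C(=O)c2cccc(-n3cc(C(C)(C)O)nn3)c2)cc1O`: 17100 nM

In a functional assay on RAW264.7 cells (Mus musculus) for inhibition, with a stated time of 4 days (on this read-out lower numbers stand for stronger inhibition and higher numbers for weaker inhibition), compound 1 gives 19800 nM and compound 2 gives 17100 nM. Within the data shown here, the only step measured so far, a 1.2-fold lower number from compound 1 to compound 2 (0.06 log units; within the scatter), swaps 3-hydroxy-4-methoxyphenyl for 4-hydroxy-3-methoxyphenyl on a double-bonded chain carbon bound to a double-bonded chain carbon and stays within the scatter. Compound 2 has the lowest of the two numbers, with compound 1 within the scatter of it.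

Compound 3 `COc1ccc(/C=C/C(=O)c2cccc(-n3cc(-c4ccc(F)cc4)nn3)c2)cc1O` differs from compound 2 by 4-fluorophenyl in place of 1-hydroxy-1-methylethyl on an aromatic carbon. Among the measured compounds shown here, no measured step touches this position on the five-membered aromatic ring with 3 nitrogen, so nothing in the data bears on the size or direction of the change; the step from compound 1 to compound 2 concerns the other end of the shared core. The estimate therefore keeps compound 3 close to compound 2, with a wide range: a 1.4-fold lower number from compound 2 to compound 3 (0.15 log units; within the scatter) is expected, giving compound 3 an estimated 12000 nM, between 3000 nM and 50000 nM in this assay.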

Compound 3, half-maximal inhibitory concentration: 2500 nM
Compound 3: middle estimate off by 4.8-fold (0.68 log units), on the high side, and the stated range ends above it.
By their numbers in this assay, from the lowest: compound 3; then compounds 2 and 1 (each within the scatter of the next).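

Among these compounds, the aromatic carbon of the five-membered aromatic ring with 3 nitrogen is the first position to show a change beyond the scatter in this assay: 4-fluorophenyl in place of 1-hydroxy-1-methylethyl gives a 6.8-fold lower number from compound 2 to compound 3 (0.84 log units; beyond the scatter). The exchange adds a six-membered aromatic ring and removes the hydroxyl-bearing group with its hydrogen-bond donor and acceptor, so this single step cannot separate the contribution of either change. No available evidence bears on the origin of the shift.

The compounds shown leave open whether the fluorine matters, as they include neither plain phenyl nor a phenyl bearing chlorine or an amine at this position. They also leave open whether 4-fluorophenyl has the same effect on the 4-hydroxy-3-methoxyphenyl side of compound 1.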